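The source may report more compounds than this note shows. Statements on the series, on what has been measured and on what is new or still open speak of the compounds shown alone.

Compounds measured so far in a functional assay on HEL cells (Homo sapiens) for cytotoxicity, read by microscopy; on this read-out higher numbers stand for lower toxicity in this test and lower numbers for higher toxicity in this test:
- compound 1 `C#CCCCc1cc2cn([C@H]3C[C@H](O)[C@@H](CO)O3)c(=O)nc2o1` – > 200000 nM, a limit of the assay, not a number
- compound 2 `C#CCCCCc1cc2cn([C@H]3C[C@H](O)[C@@H](CO)O3)c(=O)nc2o1` – > 200000 nM, likewise a limit of the assay

Compound 2 therefore stands at the upper end of the scale shown, without a numerical value; its only measured neighbour, compound 1, sits at the same limit. Going by the values given here, the one measured step, a step that the two limits leave unreadable from compound 1 to compound 2, is thus left unreadable by the two limits, and the evidence on the series is reduced to one observation: the limit of > 200000 nM in this assay, at which 2 of the 2 values shown sit.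

Compound 3 `C#CCCCCCc1cc2cn([C@H]3C[C@H](O)[C@@H](CO)O3)c(=O)nc2o1` continues the same chain by one more carbon. Its difference from compound 2: propargyl in place of ethynyl on a saturated chain carbon, four bonds along the chain from an aromatic carbon. This is the same kind of change as the measured step, moved one bond further out along the chain.

Since both measured chain lengths sit at the limit, the step of a number no higher from compound 2 to compound 3 (the limit leaves the size open) is expected to be unreadable as well, with no change beyond the scatter discernible. Compound 3 is estimated at 200000 nM, within 100000 nM to 400000 nM, most probably reported again as a limit rather than a number.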

Compound 3, minimum cytotoxic concentration: > 200000 nM
Compound 3 was reported as a limit; the forecaster's own chance of this, stated with the estimate: 85%; the middle value lies on the limit itself.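

No step among compound 1, compound 2 and compound 3 can be read in this assay, because all three sit at the same limit of the assay: the limit of > 200000 nM in this assay, at which 3 of the 3 values shown sit.

The compounds shown leave open whether any of these chain lengths gives a numerical minimum cytotoxic concentration in this assay, and how the three compounds rank against one another.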